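The compounds below may be only part of what the source reports. "The series", "measured", "known", "first", "only" and "open" are said of these compounds alone.

Compound 1 `CC(C)(NC(=O)c1ccc([N+](=O)[O-])o1)c1ccccc1` in an ADME assay on Vero cells (Chlorocebus sabaeus) for cytotoxicity, read by MTT assay, with a stated time of 48 h (a lower number here means that less compound is tolerated, a higher number that more compound is tolerated), gives > 180000 nM, which is a limit of the assay and not a number.
Compound 2 `CN(C)c1ccc(C(C)(C)NC(=O)c2ccc([N+](=O)[O-])o2)cc1` gives 79000 nM in this assay.
Compound 3 `CC(C)(NC(=O)c1ccc([N+](=O)[O-])o1)c1ccc(C(F)(F)F)cc1` gives > 150000 nM in this assay, again a limit of the assay rather than a number.

Compound 3 therefore stands at a limit, and of the three values shown one further value is also a limit, so only compound 2 gives a measured number. The step to compound 4 `CC(C)(NC(=O)c1ccc([N+](=O)[O-])o1)c1ccc(-c2ccc(Cl)cc2)cc1` is 4-chlorophenyl in place of trifluoromethyl on an aromatic carbon. Within the data shown here, two measured steps touch compound 3: an at least 1.8-fold higher number from compound 2 to compound 3 (0.27 log units; that floor lies within the scatter), and a step that the two limits leave unreadable from compound 1 to compound 3. Among the measured compounds shown here, neither gives a readable size, and nothing among the measured compounds speaks to a 4-chlorophenyl group. The expectation for compound 4 is thus no step beyond the scatter, with the outcome likely to be a limit again, as a number no higher from compound 3 to compound 4 (the limit leaves the size open) expresses. Compound 4 is estimated at 150000 nM, with a range from 40000 nM to 400000 nM.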

Compound 4, half-maximal cytotoxic concentration: > 140000 nM
Compound 4: no number, only a limit; the forecaster's own chance of this, stated with the estimate: 60%; the middle value is on the limit's open side.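

In this assay, the place on the aromatic ring that holds trifluoromethyl in compound 3 can also hold 4-chlorophenyl, which brings a second six-membered aromatic ring, and compound 4 still ends at a limit of the assay rather than a number: the limit of > 140000 nM in this assay, at which 1 of the 4 values shown sits.

Among these compounds, the only comparison that can be read is an at least 1.7-fold higher number from compound 2 to compound 4 (0.24 log units; that floor lies within the scatter), so compound 4 is not clearly set apart from the dimethylamino compound. The steps to compound 4 from compound 1 and from compound 3 cannot be read, as each joins two limits.

As far as these compounds go, the true values behind the three limits stay open, so no order among compound 1, compound 3 and compound 4 can be given. Also open, from the compounds shown here alone, is whether a carboxylic acid or a primary amine at this place would give a measured number.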